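Replacing dimethylamino with a methylpiperazine ring

The source may hold more compounds than are shown below. What is called first, only, known or untested is meant among the compounds shown, and "the series" means these compounds.

In a functional assay on HCT-116 cells (Homo sapiens) for inhibition, read by luminescence and resazurin assay, with a stated time of 3 days (on this read-out lower numbers stand for stronger inhibition and higher numbers for weaker inhibition), compound 1 `CNc1nc(NCc2ccc(C(=O)NC3CCN(Cc4ccc(F)cc4)CC3)cc2)c2cc(C)ccc2n1` gives 1200 nM. For the measured compounds named here, compound 3 `Cc1ccc2nc(N(C)C)nc(NCc3ccc(C(=O)NC4CCN(Cc5ccc(F)cc5)CC4)cc3)c2c1` gives 800 nM, and these are the only two actual numbers so far. Placing a methyl in place of hydrogen on a nitrogen on an aromatic ring accounts for a 1.5-fold lower number from compound 1 to compound 3 (0.18 log units; within the scatter), so the two compounds stand level. Compound 2 `CCNc1ncc(C)c(NCc2ccc(NC(=O)c3ccc(F)cc3)cc2)n1` has a different structure, and its > 20000 nM is a limit of the assay, not a number.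

Compound 4 `Cc1ccc2nc(N3CCNC(C)C3)nc(NCc3ccc(C(=O)NC4CCN(Cc5ccc(F)cc5)CC4)cc3)c2c1` keeps the rest of compound 3 but carries 3-methylpiperazin-1-yl in place of dimethylamino on an aromatic carbon, between two ring nitrogen atoms: 3-methylpiperazin-1-yl in place of dimethylamino on an aromatic carbon. The group that leaves has no ring, whereas the one that enters brings a six-membered non-aromatic ring with 2 hetero atoms. Going by the values given here, only one measured step touches this place, namely a 1.5-fold lower number from compound 1 to compound 3 (0.18 log units; within the scatter). It was small, but the present swap is much larger, so it offers only a loose guide. In this assay the expected change is a 1.1-fold lower number from compound 3 to compound 4 (0.06 log units; within the scatter), which means no expected shift beyond the scatter in either direction. For compound 4 the estimated value is 700 nM, with an expected range of 200 nM to 2500 nM.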

Compound 4, half-maximal inhibitory concentration: 2000 nM
For compound 4 the middle estimate is 2.9-fold (0.46 log units) below the measured one; the range from low to high includes it.
By their numbers in this assay, from the lowest: compounds 3, 1 and 4 (each within the scatter of the next, the first and the last beyond it). At a limit, above all of these: compound 2.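

The aromatic carbon between two ring nitrogen atoms is not indifferent to what it carries: in this assay the swap from dimethylamino to 3-methylpiperazin-1-yl gives a 2.5-fold higher number from compound 3 to compound 4 (0.40 log units; beyond the scatter), a modest change, but the first at this place that lies beyond the scatter. Measured against methylamino, the same ring gives a 1.7-fold higher number from compound 1 to compound 4 (0.22 log units; within the scatter), which lies within the scatter, so compound 4 stands level with compound 1 and is separated only from compound 3. The position therefore accepts a much larger group that brings a six-membered non-aromatic ring and a hydrogen-bond donor, and compound 4 still gives a real number rather than a limit of the assay, though the step from compound 3 shows that the swap is not free.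

On these data alone, it remains open whether the ring as a whole, its methyl or its ring nitrogen carrying a hydrogen sets the size of this step, and a morpholine ring or a piperazine ring without the methyl at this place would bear on that question. Nothing in the data shown gives a reason for the step.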